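The compounds below may be only part of what the source reports. "The series", "measured", "known", "first", "only" and "open" are said of these compounds alone.

Compound 1 `Cn1cncc1CN1CC(N(CC2CCN(C(=O)CNC(=O)OC(C)(C)C)CC2)S(=O)(=O)c2ccccn2)Cc2cc(C#N)ccc21` was measured in an ADME assay on Caco-2 cells (Homo sapiens) for permeability, in the apical to basolateral direction (on this read-out higher numbers stand for higher permeability and lower numbers for lower permeability), where compound 1 gives 0.5 10^-6 cm/s. Compound 2 `Cn1cncc1CN1CC(N(CC2CCN(C(=O)CC(C)(C)C)CC2)S(=O)(=O)c2ccccn2)Cc2cc(C#N)ccc21` gives 0.5 10^-6 cm/s in this assay, and the step of no change at the digits printed from compound 1 to compound 2 (within the scatter) leaves the two level, together the highest of the three numbers measured. Compound 3 `CC(C)S(=O)(=O)N1CCC(CN(C2Cc3cc(C#N)ccc3N(Cc3cncn3C)C2)S(=O)(=O)c2ccccn2)CC1` gives 0.1 10^-6 cm/s in this assay; the steps of a 5.0-fold lower number from compound 1 to compound 3 (0.70 log units; beyond the scatter) and a 5.0-fold lower number from compound 2 to compound 3 (0.70 log units; beyond the scatter) are both modest drops beyond the scatter. Compound 4 `CCS(=O)(=O)N1CCC(CN(C2Cc3cc(C#N)ccc3N(Cc3cncn3C)C2)S(=O)(=O)c2ccccn2)CC1` has not yet been measured. It differs from compound 1 in one place: ethylsulfonyl in place of (((tert-butoxycarbonyl)amino)methyl)carbonyl on an amine nitrogen in a ring. For the measured compounds named here, the steps that bear on this change are the two that lead to compound 3, where isopropylsulfonyl took the place of a carbonyl-linked group on the same amine nitrogen in a ring and the number fell: a 5.0-fold lower number from compound 1 to compound 3 (0.70 log units; beyond the scatter) and a 5.0-fold lower number from compound 2 to compound 3 (0.70 log units; beyond the scatter). Compound 4 carries ethylsulfonyl on that nitrogen, so a drop of similar size is expected, a 4.2-fold lower number from compound 1 to compound 4 (0.62 log units; beyond the scatter). Compound 4 is therefore estimated at 0.12 10^-6 cm/s in this assay, with an expected range from 0.05 10^-6 cm/s to 0.4 10^-6 cm/s.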

Compound 4, apparent permeability: 0.1 10^-6 cm/s
The estimate for compound 4 lay 1.2-fold (0.08 log units) above the measured number; the measured number falls inside the stated range.
By their numbers in this assay, from the lowest: compounds 3 and 4 (each within the scatter of the next); then compounds 1 and 2 (each within the scatter of the next).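

Shortening isopropylsulfonyl to ethylsulfonyl on the amine nitrogen in a ring gives no change at the digits printed from compound 3 to compound 4 (within the scatter) in this assay, so removing this methyl does not shift the read-out beyond the scatter. The lower level therefore holds for a second sulfonyl group, not only for isopropylsulfonyl: ethylsulfonyl gives a 5.0-fold lower number from compound 1 to compound 4 (0.70 log units; beyond the scatter) and a 5.0-fold lower number from compound 2 to compound 4 (0.70 log units; beyond the scatter), steps of the same size as those seen with isopropylsulfonyl. No measurement at hand accounts for the gap between the sulfonyl compounds and the carbonyl-linked ones.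

The compounds shown leave open whether methylsulfonyl or phenylsulfonyl on this nitrogen would stay at the level of compound 3 and compound 4. They also leave open whether a small acetyl group there would stand with compound 1 and compound 2.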